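This account rests on a few compounds, and the source may have more. Where it says the series, first, only, none or still open, it means among the compounds named here.

Measured in an ADME assay on HEK-293T cells (Homo sapiens) for cytotoxicity, read by MTT assay, with a stated time of 24 h; a lower number here means that less compound is tolerated, a higher number that more compound is tolerated:
- compound 1 `O=S(=O)(c1ccc(Cl)cc1)n1c(-c2cn(-c3ccccc3)nc2-c2ccc(F)cc2)nc2ccccc21`: 93100 nM
- compound 2 `O=S(=O)(c1ccc(Br)cc1)n1c(-c2cn(-c3ccccc3)nc2-c2ccc(F)cc2)nc2ccccc21`: 239000 nM
- compound 3 `O=S(=O)(c1ccc(C(F)(F)F)cc1)n1c(-c2cn(-c3ccccc3)nc2-c2ccc(F)cc2)nc2ccccc21`: 241000 nM

Not yet measured: compound 4 `O=S(=O)(c1ccc(Cl)cc1)n1c(-c2cn(-c3ccccc3)nc2-c2ccc(C(F)(F)F)cc2)nc2ccccc21`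

Compound 1 has the lowest number of the three, so it is the least tolerated in this assay. Compound 4 keeps the chloro group of compound 1 but differs at another place: trifluoromethyl in place of fluoro on an aromatic carbon. In words, trifluoromethyl stands in place of fluoro on an aromatic carbon, which turns 4-fluorophenyl into 4-(trifluoromethyl)phenyl.

Among the compounds with values here, no measured step makes this exact swap. The closest evidence is a 2.6-fold higher number from compound 1 to compound 3 (0.41 log units; beyond the scatter), where trifluoromethyl replaces chloro elsewhere in the molecule. Another modest change is a 2.6-fold higher number from compound 1 to compound 2 (0.41 log units; beyond the scatter), where bromo replaces chloro. Between the two larger-numbered compounds there is a 1.0-fold higher number from compound 2 to compound 3 (0.00 log units; within the scatter). These steps are only a loose guide, but they suggest a modest rise rather than a large one. The expected change is a 2.1-fold higher number from compound 1 to compound 4 (0.33 log units; beyond the scatter). For compound 4 the estimated value is 200000 nM, with an expected range of 85000 nM to 450000 nM.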

Compound 4, half-maximal cytotoxic concentration: 75300 nM
Estimate against measurement, compound 4: 2.7-fold (0.42 log units) above; the measured number lies below the stated range.
By their numbers in this assay, from the lowest: compounds 4 and 1 (each within the scatter of the next); then compounds 2 and 3 (each within the scatter of the next).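

In this assay, trifluoromethyl in place of fluoro gives a 1.2-fold lower number from compound 1 to compound 4 (0.09 log units; within the scatter), so the 4-fluorophenyl and 4-(trifluoromethyl)phenyl forms cannot be told apart by this read-out. The same group entering elsewhere in the molecule, in place of chloro, gave a 2.6-fold higher number from compound 1 to compound 3 (0.41 log units; beyond the scatter), so the effect of trifluoromethyl in this series depends on where it stands and which group it replaces. Nothing available explains why these two changes differ.

Only fluoro and trifluoromethyl are shown at this place, so it remains open whether an amine, a carboxylic acid or a longer chain there would shift the number beyond the scatter. On these data alone, it is also open whether the 4-(trifluoromethyl)phenyl form would behave the same with bromo in place of chloro.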